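Reversed amide series: from cyclohexylmethyl to phenyl on the carbonyl

The compounds below may be only part of what the source reports. "The series", "measured", "known", "first", "only" and "open" are said of these compounds alone.

Going by the values given here, the two compounds measured so far share one core and differ only in the amide region. Compound 1, `Cc1cc(C(=O)NCc2ccccc2)nn1Cc1cc(Cl)ccc1OCc1ccccc1`, gives 39.8 nM in an assay on CHO-K1 cells for displacement of a labelled ligand from prostaglandin E2 receptor EP1 subtype (Homo sapiens); on this read-out higher numbers stand for weaker inhibition and lower numbers for stronger inhibition. Compound 2, `Cc1cc(NC(=O)CC2CCCCC2)nn1Cc1cc(Cl)ccc1OCc1ccccc1`, gives 6.31 nM in this assay, the lowest of the two numbers; the change from compound 1 to compound 2, ((cyclohexylmethyl)carbonyl)amino in place of benzylcarbamoyl on an aromatic carbon, gave a 6.3-fold lower number from compound 1 to compound 2 (0.80 log units; beyond the scatter).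

Compound 3, `Cc1cc(NC(=O)c2ccccc2)nn1Cc1cc(Cl)ccc1OCc1ccccc1`, keeps the reversed amide of compound 2 and changes the group on the carbonyl: phenyl in place of cyclohexylmethyl on a carbonyl carbon. Among the compounds with values here, no measured step bears directly on this change; the only step in hand, from compound 1 to compound 2, alters the amide direction together with the group on the carbonyl, so it cannot be separated into parts. The account therefore rests on compound 2 alone, and a step of uncertain direction, at most modest, is expected in this assay, a 2.4-fold higher number from compound 2 to compound 3 (0.38 log units; beyond the scatter). For compound 3 the estimate is 15 nM, with a range from 4 nM to 60 nM.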

Compound 3, half-maximal inhibitory concentration: 15.9 nM
Estimate against measurement, compound 3: 1.1-fold (0.03 log units) below, within the range that was stated.
By their numbers in this assay, from the lowest: compound 2; then compound 3; then compound 1.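

In this assay, going by these compounds alone, the step read at this position alone gives a 2.5-fold higher number from compound 2 to compound 3 (0.40 log units; beyond the scatter) and is the first to separate the group on the carbonyl from the direction of the amide, since the earlier step changed both together. The replacement of benzylcarbamoyl by benzamido on an aromatic carbon gives a 2.5-fold lower number from compound 1 to compound 3 (0.40 log units; beyond the scatter) and shows that a reversed amide keeps a lower number than compound 1 with either phenyl or cyclohexylmethyl on the carbonyl, a pattern that none of the three compounds goes against. Still, phenyl in place of cyclohexylmethyl exchanges a non-aromatic ring for an aromatic one and also removes the link to the carbonyl, so this single step cannot assign its size to either difference. No available evidence accounts for the size of this step.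

Going by these compounds, it remains open how a cyclohexyl group attached directly to the carbonyl or a benzyl group would fall, and these two would pull apart the ring type and the link. Also open, on these data alone, is how a chlorine or a methoxy group on the phenyl ring, or a pyridine ring in its place, would change the number in this assay on this reversed amide.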